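Triazole thioacetamides: amide-side change, compound 3 to compound 4

A few compounds are considered here, and "the series" means these few. Any claim that something is new, unique, unknown or untested is made for them only; others in the source may bear on it.

Compound 1 `CCn1c(CNc2ccccc2)nnc1SCC(=O)Nc1ccc(OC)cc1` and compound 2 `CCn1nnc(-c2ccc(NC(=O)CSc3nnc(CNc4ccccc4)n3CC)cc2)n1` share the core that carries the thioacetamide anilide; the two differ only by 2-ethyl-2H-tetrazol-5-yl in place of methoxy on an aromatic carbon. In an assay on isolated protein for inhibition of long-chain fatty acid transport protein 1 (Mus musculus) (on this read-out lower numbers stand for stronger inhibition and higher numbers for weaker inhibition), compound 1 gives only a limit, > 10000 nM. In this assay compound 2 likewise gives only a limit, > 10000 nM. The step that the two limits leave unreadable from compound 1 to compound 2 is therefore not readable, since both ends sit at the limit of > 10000 nM in this assay, at which 2 of the 3 values shown sit. Compound 3 `CCn1c(CNc2ccccc2)nnc1SCC(=O)Nc1ccc(C(C)=O)cc1` has no number in this assay, "not determined" (no result reported). Only compound 1 and compound 2 have values shown for the series, so compound 3 stands nowhere on the scale. Compound 4 `CCn1c(CNc2ccccc2)nnc1SCC(=O)Nc1ccc(C(=O)NC)cc1` differs from compound 3 as follows: methylamino in place of methyl on a carbonyl carbon. No measured step bears on this change, and the one step shown is itself unreadable. With two of three values at the limit, compound 4 is expected to give roughly 15000 nM, in a range from 3000 nM to 60000 nM, most likely as a limit again.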

Compound 4, half-maximal inhibitory concentration: > 10000 nM
Compound 4 ended at the assay's limit; the forecaster's own chance of this, stated with the estimate: 70%; the middle value is on the limit's open side.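

Compound 4 gives no new readable step: the steps from compound 1 and compound 2 to compound 4 join limits, not numbers: the limit of > 10000 nM in this assay, at which 3 of the 4 values shown sit.

The compounds shown leave open whether methoxy, 2-ethyl-2H-tetrazol-5-yl and methylcarbamoyl differ at all in this assay.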